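A few compounds are considered here, and "the series" means these few. Any claim that something is new, unique, unknown or untested is made for them only; others in the source may bear on it.

The measured compounds:

Compound 1, `CCC1C(=O)N(C)c2cnc(-n3ccc4cc(C(N)=O)ccc43)nc2N1c1ccn(C)n1`, gives 39500 nM in a functional assay on A549 cells (Homo sapiens) for antiproliferative activity, read by CCK-8 assay, with a stated time of 72 h; a lower number here means a stronger inhibitor of growth, a higher number a weaker inhibitor of growth.
Compound 2, `CCCCNS(=O)(=O)c1ccc(Nc2ncc3c(n2)N(c2ccn(C)n2)C(CC)C(=O)N3C)cc1`, gives 10600 nM in this assay.
Compound 3, `CCC1C(=O)N(C)c2cnc(-n3ccc4cc(C(=O)NCC(C)C)ccc43)nc2N1c1ccn(C)n1`, gives 19200 nM in this assay.

Compound 2 stands with the lowest number of the three. Its gap to compound 3 lies within the scatter, so no order between those two can be claimed; its gap to compound 1 lies beyond the scatter. Compound 2 differs from compound 1 and from compound 3 in more than one place, so those values serve only as a backdrop. Among the measured compounds shown here, the single step between measured compounds is a 2.1-fold lower number from compound 1 to compound 3 (0.31 log units; beyond the scatter), where an alkyl group entered on an amide-type nitrogen and the number fell modestly.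

Compound 4, `CCC1C(=O)N(C)c2cnc(Nc3ccc(S(N)(=O)=O)cc3)nc2N1c1ccn(C)n1`, is reached from compound 2 by hydrogen in place of butyl on a sulfonamide nitrogen. For the measured compounds named here, this is the reverse kind of change to the one measured step: an alkyl group leaves a nitrogen instead of entering one. Taking that step as the only guide, a modest rise in the number is expected, of about a 1.9-fold higher number from compound 2 to compound 4 (0.28 log units; within the scatter) in this assay. The estimate for compound 4 in this assay is therefore 20000 nM, with a range from 8000 nM to 50000 nM.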

Compound 4, concentration for 50% growth inhibition: "not active" (no number reported)
Nothing numeric was reported for compound 4, and the estimate cannot be compared.
By their numbers in this assay, from the lowest: compounds 2 and 3 (each within the scatter of the next); then compound 1.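

In this assay, among the compounds shown here, compound 4 is reported only as not active, with no number, so no step from compound 2 to compound 4 can be read. The compounds shown leave open how far the exchange of butylsulfamoyl for sulfamoyl shifts growth inhibition. No supporting evidence bears on this result.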